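The compounds below may be only part of what the source reports. "The series", "measured", "known", "first", "only" and "open" are said of these compounds alone.

Measured compounds:
compound 1 `CC(NC(=O)C(=O)Nc1c(C#N)cnn1-c1ccccc1)c1ccccc1` gives 51%
compound 2 `C[C@@H](NC(=O)C(=O)Nc1c(C#N)cnn1-c1ccccc1)c1ccccc1` gives 39%

Both numbers come from a functional assay on the whole organism (strain Wistar albino) for inhibition, with Rattus norvegicus as the target, with a stated time of 7 days, at a dose of 20 mg/kg by the oral route; a higher number here means more inhibition at the dose given (going by the name of the read-out), a lower number less inhibition. Compound 1 and compound 2 have the same atoms and bonds; they differ only at one stereocentre at a saturated chain carbon, drawn without a configuration in compound 1 and R in compound 2. That single change gives a number 12 percentage points lower from compound 1 to compound 2 (beyond the scatter), and the reason the two are looked at side by side is the fact that one of compounds 1 and 2 is drawn with a defined configuration and the other without, at the place where they differ. On the numbers shown, compound 2 stands lowest of the two, with compound 1 the nearest value above it.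

Compound 3 `C[C@H](NC(=O)C(=O)Nc1c(C#N)cnn1-c1ccccc1)c1ccccc1` is the compound to be measured. Its relation to compound 2 is the two compounds have the same atoms and bonds and differ only in configuration as drawn: 1 of 1 stereo elements differ; a stereocentre at a saturated chain carbon is drawn R in compound 2 and S in compound 3. Going by the values given here, the only measured step that bears on this is the step from compound 1 to compound 2, a modest drop beyond the scatter; since compound 1 is drawn without a configuration while compound 3 carries the opposite configuration to compound 2, the expectation is a rise, a number 21 percentage points higher from compound 2 to compound 3 (beyond the scatter), in the same assay. Compound 3 is therefore estimated at 60%, with a range from 38% to 80%.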

Compound 3, a percentage reported as inhibition, in the whole organism at one dose (the size of the read-out at that dose, not a potency): 49%
Beside the measured number, compound 3's estimate is 11 percentage points above it, within the range that was stated.
By their numbers in this assay, from the lowest: compounds 2, 3 and 1 (each within the scatter of the next, the first and the last beyond it).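

In this assay, inverting the one stereocentre at the saturated chain carbon gives a number 10 percentage points higher from compound 2 to compound 3 (within the scatter), so this result gives no firm separation between the R and S forms: the fact that compounds 2 and 3 differ only in the configuration as drawn

The S form also cannot be told apart from the compound drawn without a configuration, with a number 2 percentage points lower from compound 1 to compound 3 (within the scatter): the fact that one of compounds 1 and 3 is drawn with a defined configuration and the other without, at the place where they differ

The earlier step, a number 12 percentage points lower from compound 1 to compound 2 (beyond the scatter), remains beyond the scatter, yet compound 3 lies within the scatter of both compound 1 and compound 2, so the three values do not establish a clear preference for either configuration at this position.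

Going by these compounds, a single oral dose shows the size of the read-out at that dose, not a potency, so it remains open whether the R and S forms would separate at other doses. On these data alone, it is also open whether a larger group at this stereocentre, such as an ethyl group or a longer chain in place of the methyl, or a carboxylic acid on the phenyl ring, would make the configuration matter beyond the scatter.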